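Dropping a Methoxy Group: Expected Effect on Growth Inhibition

The source may hold more compounds than are shown below. What is called first, only, known or untested is meant among the compounds shown, and "the series" means these compounds.

Compound 1 `COc1cc(-c2cc(/C=C/C(=O)c3ccc(N)cc3)[nH]n2)cc(OC)c1OC` gives 1780 nM in a functional assay on OVCAR-5 cells (Homo sapiens) for inhibition, read by sulforhodamine B assay, with a stated time of 48 h; on this read-out higher numbers stand for weaker inhibition of growth and lower numbers for stronger inhibition of growth.
Compound 2 `COc1ccc(-c2cc(/C=C/C(=O)c3ccc(OC)c(OC)c3)[nH]n2)cc1` gives 1650 nM in this assay.
Compound 3 `COc1cc(-c2cc(/C=C/C(=O)c3ccc(Cl)c(Cl)c3)[nH]n2)cc(OC)c1OC` gives 20500 nM in this assay.

Among these three numbers compound 1 stands second highest. Its nearest neighbour is compound 2, whose value lies within the scatter of that of compound 1, so the two cannot be told apart. The furthest is compound 3, reached by a 12-fold higher number from compound 1 to compound 3 (1.06 log units; beyond the scatter), a large change that comes from swapping the group on the carbonyl carbon.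

The unmeasured compound 4 `COc1ccc(-c2cc(/C=C/C(=O)c3ccc(N)cc3)[nH]n2)cc1OC` differs from compound 1 at a different place: hydrogen in place of methoxy on an aromatic carbon. Among the compounds with values here, none of the measured steps touches this position; the one measured step alters the carbonyl-bearing ring instead, so it gives no direct guide. Within the data shown here, the only hint comes from compounds 1 and 2, which carry different numbers of methoxy groups on the shared core and differ in other ways as well, yet show values within the scatter of each other.

Compound 4 is therefore expected to give 2000 nM, within a range from 800 nM to 5000 nM. The expected step of a 1.1-fold higher number from compound 1 to compound 4 (0.05 log units; within the scatter) is estimated to stay within the scatter.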

Compound 4, concentration for 50% growth inhibition: 2620 nM
For compound 4 the middle estimate is 1.3-fold (0.12 log units) below the measured one; low and high end bracket the measured number.
By their numbers in this assay, from the lowest: compounds 2, 1 and 4 (each within the scatter of the next); then compound 3.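

In this assay, within the data shown here, this is the first direct reading at this position, and hydrogen in place of methoxy on an aromatic carbon, ortho to a methoxy group, gives a 1.5-fold higher number from compound 1 to compound 4 (0.17 log units; within the scatter). So compound 4, which keeps the aminophenyl group on the carbonyl carbon, cannot be told apart from compound 1 by this read-out, and this one methoxy group is not needed to hold growth inhibition at the level seen for compound 1. The change on the carbonyl side behaves differently, since that single swap gives a 12-fold higher number from compound 1 to compound 3 (1.06 log units; beyond the scatter), and nothing shown here accounts for the small size of the methoxy step.

The compounds shown leave open what an ethoxy group, a hydroxyl group or a fluorine atom would do at this same position, and whether the remaining methoxy groups on this ring could also give way to hydrogen with as small a step. Going by these compounds, it also stays open whether the same replacement would give a similar result alongside the 3,4-dichlorophenyl group of compound 3.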